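Swapping an Allyl for a Methylpyrazole on an Amide Nitrogen

The source may report more compounds than this note shows. Statements on the series, on what has been measured and on what is new or still open speak of the compounds shown alone.

Measured compounds:
Compound 1, `Cc1ccc(OCC(=O)N(Cc2cccs2)C(C)(C)C)cc1`: 11000 nM
Compound 2, `C=CCN(Cc1cccs1)C(=O)COc1ccc(C)cc1`: 20 nM

Both compounds were tested in an assay on HEK293 cells for agonist activity at transient receptor potential cation channel subfamily M member 8 (Homo sapiens), read by fluorescence and calcium flux, with a stated time of 15 min; a lower number here means that less compound is needed, a higher number that more compound is needed for the effect. For the measured compounds named here, compound 2 stands at the lower of the two numbers in this assay; the only other measured compound is compound 1, and the two are separated by a single change on the amide-type nitrogen: a 550-fold lower number from compound 1 to compound 2 (2.74 log units; beyond the scatter).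

Compound 3, `Cc1ccc(OCC(=O)N(Cc2cccs2)c2cnn(C)c2)cc1`, has not yet been measured. It differs from compound 2 in one place: 1-methyl-1H-pyrazol-4-yl in place of allyl on an amide-type nitrogen. Going by the values given here, only one measured step bears on this change, and it is the same one, a 550-fold lower number from compound 1 to compound 2 (2.74 log units; beyond the scatter). That step shows that the group on this nitrogen can move the number by a large amount, but it compares two groups of which neither is the entering one, so it fixes neither the direction nor the size for compound 3. The entering group is a flat aromatic ring rather than a short open chain, which is a larger departure from compound 2 than the data cover.

With this in mind, compound 3 is expected to need more compound than compound 2, as a step of a 25-fold higher number from compound 2 to compound 3 (1.40 log units; beyond the scatter), with broad uncertainty. The estimate for compound 3 in this assay is 500 nM, with a range from 50 nM to 5000 nM.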

Compound 3, half-maximal effective concentration: 63000 nM
Compound 3: the middle estimate sits 130-fold (2.10 log units) below what was measured; the measured number lies above the stated range.
By their numbers in this assay, from the lowest: compound 2; then compound 1; then compound 3.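

In this assay there is a 3200-fold higher number from compound 2 to compound 3 (3.50 log units; beyond the scatter), so on this amide-type nitrogen the 1-methyl-1H-pyrazol-4-yl ring does not keep the low number that allyl gives. The same ring also compares poorly with tert-butyl, the group that had marked the high end so far, with a 5.7-fold higher number from compound 1 to compound 3 (0.76 log units; beyond the scatter) as the modest step between them. The earlier pair showed only that this position can move the number a long way, whereas the three compounds together show allyl alone at the low end, with two very different groups both far above it, and nothing measured here explains this result.

The compounds shown leave open whether propyl, the saturated chain of the same length as allyl, or a longer chain such as butyl would stay near the low number of compound 2. They also leave open whether a plain phenyl ring would do as poorly as the pyrazole, which would help separate the effect of having any aromatic ring here from that of the two ring nitrogens.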